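The compounds below may be only part of what the source reports. "The series", "measured", "known", "first", "only" and "open" are said of these compounds alone.

Three compounds share one core and were tested in a functional assay on MKN-74 cells (Homo sapiens) for antiproliferative activity, with a stated time of 24 h; a lower number here means a stronger inhibitor, a higher number a weaker inhibitor. Compound 1 `NC(=O)c1c(NC(=O)c2ccccc2Cl)sc2c1CCN(Cc1ccccc1Cl)C2` gives 4430 nM. Compound 2 `NC(=O)c1c(NC(=O)c2ccccc2Cl)sc2c1CCN(C(=S)Nc1ccccc1)C2` gives 15600 nM, and compound 3 `NC(=O)c1c(NC(=O)c2ccccc2Cl)sc2c1CCN(C(=S)Nc1ccccc1Br)C2` gives 10800 nM. The replacement of the chlorobenzyl group produced a 3.5-fold higher number from compound 1 to compound 2 (0.55 log units; beyond the scatter) and a 2.4-fold higher number from compound 1 to compound 3 (0.39 log units; beyond the scatter), both beyond the scatter, whereas adding the halogen to the thiourea ring gave only a 1.4-fold lower number from compound 2 to compound 3 (0.16 log units; within the scatter), which is within the scatter. Compound 3 therefore sits within the scatter of compound 2 and beyond it from compound 1, the latter having the lower number of the set.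

Compound 4 `COc1ccccc1NC(=S)N1CCc2c(sc(NC(=O)c3ccccc3Cl)c2C(N)=O)C1` differs from compound 3 by methoxy in place of bromo on an aromatic carbon. For the measured compounds named here, the only measured step at this position is a 1.4-fold lower number from compound 2 to compound 3 (0.16 log units; within the scatter), and it is within the scatter, so a further swap there is expected to move the number little, if at all. Compound 4 is expected to give about 12000 nM in this assay, somewhere between 5000 nM and 30000 nM, which amounts to an expected step of a 1.1-fold higher number from compound 3 to compound 4 (0.05 log units; within the scatter).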

Compound 4, half-maximal inhibitory concentration: 35200 nM
Beside the measured number, compound 4's estimate is 2.9-fold (0.47 log units) below it; measured number outside the range, above it.
By their numbers in this assay, from the lowest: compound 1; then compounds 3 and 2 (each within the scatter of the next); then compound 4.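

In this assay, the aromatic carbon that had changed little when bromo replaced hydrogen proves sensitive to the group placed there: methoxy in place of bromo gives a 3.3-fold higher number from compound 3 to compound 4 (0.51 log units; beyond the scatter) and methoxy in place of hydrogen gives a 2.3-fold higher number from compound 2 to compound 4 (0.35 log units; beyond the scatter), both beyond the scatter. Bromo and hydrogen stay within the scatter of each other here, so this position does not treat all substituents alike, and methoxy is the one that stands apart. Compound 4 also lies furthest from the benzyl compound, with a 7.9-fold higher number from compound 1 to compound 4 (0.90 log units; beyond the scatter) as the largest step in the set.

Nothing measured here explains why methoxy differs from bromo and hydrogen. On these data alone, whether a hydroxyl, an amine or a methyl on this carbon would track with methoxy or with bromo remains open.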